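Methyl removal from the bicyclic core: a second instance

The source may report more compounds than this note shows. Statements on the series, on what has been measured and on what is new or still open speak of the compounds shown alone.

Compound 1 `Oc1cc(-c2ccc3ccccc3c2)nc2ncccc12` carries no methyl on the shared core, and in a functional assay on MDA-MB-435 cells (Homo sapiens) for antiproliferative activity (a higher number here means a weaker inhibitor of growth, a lower number a stronger inhibitor of growth), compound 1 gives 1780 nM. Compound 3 `Cc1ccnc2nc(-c3ccc4ccccc4c3)cc(O)c12` bears one methyl on that core, and in this assay compound 3 gives 204 nM. The change from compound 3 to compound 1 is hydrogen in place of methyl on an aromatic carbon and it produced the step of an 8.7-fold higher number from compound 3 to compound 1 (0.94 log units; beyond the scatter). Compound 2 `Cc1cc(C)c2c(O)cc(-c3cccc4ccccc34)nc2n1` carries two methyl groups on the core; in this assay compound 2 gives 191 nM, which lies within the scatter of compound 3. The difference between the cores of compound 2 and compound 3 is not broken down here.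

Compound 4 `Cc1ccc2c(O)cc(-c3cccc4ccccc34)nc2n1` is the next member and has not been measured. The change from compound 2 to compound 4 is hydrogen in place of methyl on an aromatic carbon. Its place is described with one further feature, meta to a methyl group (1 heavy atom), so this is the same kind of change as from compound 3 to compound 1 and not the same change. Among the measured compounds shown here, only one measured instance of removing a methyl from the core exists, and nothing shows whether the remaining methyl in compound 4 alters the outcome. The expected step to compound 4 is a 7.3-fold higher number from compound 2 to compound 4 (0.87 log units; beyond the scatter), set beside the measured 8.7-fold higher number from compound 3 to compound 1 (0.94 log units; beyond the scatter), and it rests on that single prior step alone. For compound 4 the estimate in this assay is 1400 nM, with a likely range from 500 nM to 4000 nM.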

Compound 4, concentration for 50% growth inhibition: < 10 nM
Compound 4 ended at the assay's limit; the forecaster's own chance of this, stated with the estimate: 5%; middle value at least 140-fold (2.14 log units) away from the limit.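

The replacement of methyl by hydrogen on an aromatic carbon does not carry over from one core to the other in this assay: it gave an at least 19-fold lower number from compound 2 to compound 4 (1.28 log units; beyond the scatter), opposite in direction to an 8.7-fold higher number from compound 3 to compound 1 (0.94 log units; beyond the scatter), and the two steps disagree: the same change on two cores in this assay, an 8.7-fold higher number (0.94 log units; beyond the scatter) from compound 3 to compound 1 and an at least 19-fold lower number (1.28 log units; beyond the scatter) from compound 2 to compound 4, at least 160-fold (2.22 log units) apart, beyond the scatter of two such steps

Compound 4 stands at < 10 nM, which is a limit of the assay and not a number, so the step to it has a bound but no exact size: the limit of < 10 nM in this assay, at which 1 of the 4 values shown sits.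

What this does not show is which structural feature sets the direction of the step: there is one pair per core, and the two pairs differ in more than the remaining methyl, so the reversal cannot be assigned to that methyl or to any other single feature.

Open, going by these compounds, is how a core with no methyl would behave when it carries the same aryl group as compound 2 and compound 4, since that comparison would separate the effect of the methyl from that of the aryl group. Also open, on these data alone, is whether ethyl, methoxy or an amine in place of the methyl, on the aromatic carbon opposite the ring nitrogen, would follow compound 4 or compound 2 in this series.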